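The source may report more compounds than this note shows. Statements on the series, on what has been measured and on what is new or still open speak of the compounds shown alone.

Compound 1 `C(=C1\CCN=C1c1cccnc1)\c1ccccc1` in an assay for displacement of a labelled ligand from Nicotinic acetylcholine receptor alpha8 subunit (Periplaneta americana), read by scintillation counting, with a stated time of 2 h, at 24 degrees C (on this read-out higher numbers stand for weaker inhibition and lower numbers for stronger inhibition), gives > 10000 nM, which is a limit of the assay and not a number. Compound 2 `Oc1cccc(/C=C2\CCN=C2c2cccnc2)c1` gives > 10000 nM, again only a limit. Compound 3 `COc1ccc(/C=C2\CCN=C2c2cccnc2)cc1` gives > 10000 nM, also a limit.

Compound 2 thus stands at a limit, as do the two further values shown, so its place among them cannot be read. Compound 4 `COc1cccc(/C=C2\CCN=C2c2cccnc2)c1` differs from compound 2 by methyl in place of hydrogen on an oxygen on an aromatic ring. Going by the values given here, the steps that bear on this change are a step that the two limits leave unreadable from compound 1 to compound 2 and a step that the two limits leave unreadable from compound 1 to compound 3, and both are unreadable in size because of the limit of > 10000 nM in this assay, at which 3 of the 3 values shown sit. Compound 3, which also carries a methoxy group, sits at that same limit. Compound 4 is therefore expected to give 20000 nM, within 8000 nM to 60000 nM, an expected step that the limit leaves unreadable from compound 2 to compound 4 that most likely leaves it at a limit as well.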

Compound 4, half-maximal inhibitory concentration: > 10000 nM
Compound 4: only a limit was reported (the forecaster's own chance of this, stated with the estimate: 85%); the middle value lies beyond the limit too.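

No step from compound 1 or compound 2 to compound 4 can be read, because every value is only a limit: the limit of > 10000 nM in this assay, at which 4 of the 4 values shown sit.

The compounds shown leave open whether hydroxy or methoxy changes inhibition at all in this assay.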